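A few compounds are considered here, and "the series" means these few. Any claim that something is new, unique, unknown or untested is made for them only; others in the source may bear on it.

Measured so far:
Compound 1 `O=C(COc1ccc2c(=O)ccoc2c1)Nc1cccc(NC(=O)c2ccc(Br)cc2)c1` gives 303 nM in an assay on isolated protein for inhibition of Rho-associated protein kinase 1 (Homo sapiens), read by scintillation counting, radiometric assay and 33P incorporation, with a stated time of 40 min, in the presence of a further agent that is not named here; on this read-out higher numbers stand for weaker inhibition and lower numbers for stronger inhibition.
Compound 2 `Cn1ccc(S(=O)(=O)Nc2cccc(NC(=O)COc3ccc4c(=O)ccoc4c3)c2)n1` gives > 10000 nM in this assay, which is a limit of the assay and not a number.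

Compound 2 therefore stands only at a limit in this assay, with no number of its own. Compound 1 gives 303 nM. For the measured compounds named here, the one measured step, an at least 33-fold higher number from compound 1 to compound 2 (1.51 log units; beyond the scatter), rests on (the limit of > 10000 nM in this assay, at which 1 of the 2 values shown sits), so its true size is not known beyond that bound.

Compound 3 `Nc1cccc(C(=O)Nc2cccc(NC(=O)COc3ccc4c(=O)ccoc4c3)c2)c1` differs from compound 2 by a group of 9 heavy atoms (7 carbon, 1 nitrogen, 1 oxygen; one six-membered aromatic ring of carbon only) in place of a group of 9 heavy atoms (4 carbon, 2 nitrogen, 2 oxygen, 1 sulfur; one five-membered aromatic ring with 2 hetero atoms), on a nitrogen on an aromatic ring. This is the same nitrogen at which the measured step was taken, and the entering group, like the group of compound 1, is a carbonyl on a six-membered carbon ring, so the step is expected to run in the opposite direction to the measured one and to be large. For compound 3 the expected step is an at least 20-fold lower number from compound 2 to compound 3 (1.30 log units; beyond the scatter). Compound 3 is estimated at 500 nM, with a range from 100 nM to 3000 nM.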

Compound 3, half-maximal inhibitory concentration: 670 nM
Compound 3: middle estimate off by 1.3-fold (0.13 log units), on the low side; the range from low to high includes it.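

On these data alone, putting (3-aminophenyl)carbonyl on this nitrogen gives an at least 14-fold lower number from compound 2 to compound 3 (1.17 log units; beyond the scatter), so carrying a group of this heavy-atom count on the nitrogen does not by itself leave the compound at the weak end, though the true size of this step stays unknown: the limit of > 10000 nM in this assay, at which 1 of the 3 values shown sits. The value of compound 2 is a limit and not a number. Between the two groups on a carbonyl carbon, 3-aminophenyl in place of 4-bromophenyl gives a 2.2-fold higher number from compound 1 to compound 3 (0.34 log units; beyond the scatter), a modest but readable step.

Compound 1 and compound 3 differ both in the substituent and in its place on the ring, so the two changes are not separated here. As far as these compounds go, a 4-aminophenyl or 3-bromophenyl group on the same carbonyl carbon would separate them, and how an unsubstituted phenyl or a carboxylic acid there would read remains open.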